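Amide to Oxadiazole Exchange on the Shared Core

The compounds below may be only part of what the source reports. "The series", "measured", "known", "first", "only" and "open" are said of these compounds alone.

Compound 1 `CCN(CC)S(=O)(=O)c1ccc(S(=O)(=O)N2CCC[C@@H](C(=O)N(C)C(C)C)C2)cc1` was tested in a functional assay on MIA PaCa-2 cells (Homo sapiens) for inhibition, read by MTT assay, with a stated time of 3 days; on this read-out higher numbers stand for weaker inhibition and lower numbers for stronger inhibition. In this assay compound 1 gives > 10000 nM, which is a limit of the assay and not a number. Compound 2 `CCN(CC)S(=O)(=O)c1ccc(S(=O)(=O)N2CCC[C@@H](C(=O)NC3CN(C(=O)C4CC4)C3)C2)cc1` likewise reaches only a limit, > 10000 nM. Compound 3 `CCOC(=O)[C@@H]1C[C@@H](O)CN(S(=O)(=O)c2ccc(S(=O)(=O)N(CC)CC)cc2)C1` also stops at a limit, > 10000 nM. The step that the two limits leave unreadable from compound 1 to compound 2 cannot be read because of the limit of > 10000 nM in this assay, at which 3 of the 3 values shown sit. Compound 4 `CCN(CC)S(=O)(=O)c1ccc(S(=O)(=O)N2CCC[C@@H](c3nc(C)no3)C2)cc1` differs from compound 1 by 3-methyl-1,2,4-oxadiazol-5-yl in place of isopropyl(methyl)carbamoyl on a saturated ring carbon. Within the data shown here, no measured step bears directly on this change, and every measured value sits at the limit. Compound 4 is therefore expected to remain weak, with an estimated step that the limit leaves unreadable from compound 1 to compound 4. For compound 4 the estimated value in this assay is 20000 nM, within a range from 5000 nM to 80000 nM.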

Compound 4, half-maximal inhibitory concentration: > 10000 nM
Compound 4 was reported as a limit; the forecaster's own chance of this, stated with the estimate: 80%; the middle value lies beyond the limit too.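

No step can be read between compound 1 and compound 4 because both stop at a limit of the assay: the limit of > 10000 nM in this assay, at which 4 of the 4 values shown sit.

The compounds shown leave open how 3-methyl-1,2,4-oxadiazol-5-yl and isopropyl(methyl)carbamoyl compare on the shared core.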